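The source may report more compounds than this note shows. Statements on the series, on what has been measured and on what is new or still open speak of the compounds shown alone.

Working notes on the series. For the measured compounds named here, compound 2 `CSC[C@H](NC(=O)c1ccc(C#Cc2ccccc2)cc1)C(=O)NO` stands lowest of the two numbers known in a physicochemical assay for solubility; on this read-out higher numbers stand for higher solubility and lower numbers for lower solubility: compound 2 gives 2000 nM, while compound 1 `COCCNC(=O)C[C@H](NC(=O)c1ccc(C#Cc2ccccc2)cc1)C(=O)NO` gives 78000 nM. Going by the values given here, the only step recorded so far, a 39-fold lower number from compound 1 to compound 2 (1.59 log units; beyond the scatter), is the relevant comparison: methylsulfanyl in place of (2-methoxyethyl)carbamoyl lowered this assay sharply.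

Compound 3 `O=C(N[C@H](CO)C(=O)NO)c1ccc(C#Cc2ccccc2)cc1` has not yet been measured. Relative to compound 2 the change is a group of 7 heavy atoms (3 carbon, 1 nitrogen, 3 oxygen; no ring) in place of a group of 8 heavy atoms (4 carbon, 1 nitrogen, 2 oxygen, 1 sulfur; no ring), on an amide-type nitrogen. The group that enters counts three hydrogen-bond donors against two in the group that leaves, and carries no sulfur. Given that compound 2 sits at 2000 nM after the large drop of a 39-fold lower number from compound 1 to compound 2 (1.59 log units; beyond the scatter), a rise back toward the number of compound 1 is expected, though not necessarily all the way, so the step of a 13-fold higher number from compound 2 to compound 3 (1.10 log units; beyond the scatter) is estimated as upward and beyond the scatter. For compound 3 the estimate in this assay is 25000 nM, with a range from 6000 nM to 100000 nM.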

Compound 3, solubility: 36000 nM
For compound 3 the middle estimate is 1.4-fold (0.16 log units) below the measured one, within the range that was stated.
By their numbers in this assay, from the lowest: compound 2; then compound 3; then compound 1.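

In this assay this position now moves in both directions: the change to the group of 7 heavy atoms gives an 18-fold higher number from compound 2 to compound 3 (1.26 log units; beyond the scatter), so a low number does not simply follow from the loss of the (2-methoxyethyl)carbamoyl group seen in the earlier step. A group with no sulfur and no ring restores a high number here, with compound 3 at 36000 nM and compound 1 at 78000 nM on the same read-out. Nothing at hand gives a measured reason for this rise.

The compounds shown do not separate the part played by the sulfur from that of the hydroxyl-bearing chain of compound 3, as the two differ together. As far as these compounds go, how a carboxylic acid, an amine or a longer chain carrying a hydroxyl would read at this place remains open.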